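This account rests on a few compounds, and the source may have more. Where it says the series, first, only, none or still open, it means among the compounds named here.

Measured so far:
compound 1 `CC(=O)OCc1ccc2oc(=O)c(C(=O)Oc3cccc(Br)c3)cc2c1` gives 11.8% in a functional assay on HT-1080 cells (Homo sapiens), read by transwell migration, with a stated time of 24 h, tested at 10 uM; a lower number here means a stronger effect, a higher number a weaker effect of the compound at the concentration tested
compound 2 `CCCCC(=O)OCc1ccc2oc(=O)c(C(=O)Oc3cccc(Br)c3)cc2c1` gives 32.3% in this assay

For the measured compounds named here, of these two numbers compound 2 stands highest, with compound 1 as its only neighbour, a number 20.5 percentage points higher from compound 1 to compound 2 (beyond the scatter). That lone step, propyl in place of hydrogen on a saturated chain carbon bound to a carbonyl carbon, is the only one that bears on the next change. Compound 3 `CCCCCCC(=O)OCc1ccc2oc(=O)c(C(=O)Oc3cccc(Br)c3)cc2c1` has not yet been measured; it differs from compound 2 by ethyl in place of hydrogen on a saturated chain carbon, four bonds along the chain from a carbonyl carbon. Going by the values given here, the one measured step grew the same chain and raised the read-out by a modest margin beyond the scatter, so a further rise is expected here as well, though a single step cannot show whether the pattern holds. The expected step is therefore a number 9.7 percentage points higher from compound 2 to compound 3 (within the scatter), a rise of similar or smaller size. The estimate for compound 3 is 42%, within 22% to 65%.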

Compound 3, a percentage reported as activity, at one concentration (the size of the read-out at that concentration, not a potency): 36%
Beside the measured number, compound 3's estimate is 6 percentage points above it; measured number inside the range.
By their numbers in this assay, from the lowest: compound 1; then compounds 2 and 3 (each within the scatter of the next).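

In this assay, ethyl in place of hydrogen on a saturated chain carbon, four bonds along the chain from a carbonyl carbon, gives a number 3.7 percentage points higher from compound 2 to compound 3 (within the scatter), so at this place the further growth of the chain brings no change that can be told from the scatter. The full growth of the chain gives a number 24.2 percentage points higher from compound 1 to compound 3 (beyond the scatter), so the longer chain stays clear of the scatter around the acetyl ester, as the shorter one did. Nothing at hand gives a reason for either step.

From the compounds shown here alone, whether a longer chain would stay within the scatter of these values remains open. So does what an amine or a carboxylic acid at the end of the chain would do to the read-out.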